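A few compounds are considered here, and "the series" means these few. Any claim that something is new, unique, unknown or untested is made for them only; others in the source may bear on it.

Measured so far:
- compound 1, `C#Cc1ccnc(C#Cc2ccc3ncn(-c4ccnc(N)n4)c3c2)c1`: 316 nM
- compound 2, `C=Cc1ccnc(C#Cc2ccc3ncn(-c4ccnc(N)n4)c3c2)n1`: 1580 nM

Both numbers come from an assay on Sf9 cells for inhibition of mitogen-activated protein kinase kinase kinase 14 variant S549D (Homo sapiens), with a stated time of 30 min, in the presence of a further agent that is not named here; on this read-out lower numbers stand for stronger inhibition and higher numbers for weaker inhibition. For the measured compounds named here, compound 2 stands at the higher of the two, and the only measured step, a 5.0-fold higher number from compound 1 to compound 2 (0.70 log units; beyond the scatter), moves away from compound 1 by a margin that the assay's own scatter does not explain. That step, however, changes two things at once: the six-membered aromatic ring with 1 hetero atom becomes one with 2 hetero atoms, and a triple bond outside aromatic rings becomes a double bond.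

Compound 3, `C#Cc1nccc(C#Cc2ccc3ncn(-c4ccnc(N)n4)c3c2)n1`, keeps the six-membered aromatic ring with 2 hetero atoms of compound 2 and differs from it in this way: a group of 8 heavy atoms (6 carbon, 2 nitrogen; one six-membered aromatic ring with 2 hetero atoms) in place of a group of 8 heavy atoms (6 carbon, 2 nitrogen; one six-membered aromatic ring with 2 hetero atoms), on a triple-bonded carbon. The change thus undoes only the double-for-triple part of the earlier step, and the measured data cannot say how much of that step belonged to each part. A partial return toward compound 1 is the most plausible reading, but a step staying within the scatter is possible too.

On that basis compound 3 is expected to give 700 nM in this assay, with a likely range from 250 nM to 2000 nM; this amounts to an expected step of a 2.3-fold lower number from compound 2 to compound 3 (0.35 log units; beyond the scatter).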

Compound 3, half-maximal inhibitory concentration: 39800 nM
Compound 3: middle estimate off by 57-fold (1.75 log units), on the low side; the measured number lies above the stated range.
By their numbers in this assay, from the lowest: compound 1; then compound 2; then compound 3.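

Replacing the double bond outside aromatic rings with a triple bond, while keeping a six-membered aromatic ring with 2 hetero atoms, brings no return toward compound 1: instead there is a 25-fold higher number from compound 2 to compound 3 (1.40 log units; beyond the scatter), even though the two groups match in every count and differ also in how their rings are substituted. A triple bond outside aromatic rings is therefore not enough on its own to hold the number low, as a 130-fold higher number from compound 1 to compound 3 (2.10 log units; beyond the scatter) shows, although compound 1 and compound 3 both carry one, so the group on this triple-bonded carbon is far more sensitive to its exact make-up than the first step suggested. No separate measurement explains these steps.

The compounds shown leave open how much of these steps belongs to the extra ring nitrogen, how much to the way the ring is substituted, and how much to the double or triple bond, as no pair here varies just one of these. They also leave open how this assay would read a nitrile or an amine in place of the triple bond on the ring of compound 1.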